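A few compounds are considered here, and "the series" means these few. Any claim that something is new, unique, unknown or untested is made for them only; others in the source may bear on it.

Working notes on the series in an ADME assay on BJ cells (Homo sapiens) for cytotoxicity, with a stated time of 72 h; on this read-out lower numbers stand for an effect already at smaller amounts and higher numbers for an effect only at larger amounts of compound. Compound 1 `Cc1cc(NC(=O)Nc2ccc(Cl)c(Cl)c2)c2ccccc2n1` gives 23000 nM and compound 2 `CC(=O)c1ccc(NC(=O)Nc2cc(C)nc3ccccc23)cc1` gives 22000 nM, two numbers within the scatter of each other, so compound 2 does not separate from compound 1. Compound 3 `Cc1cc(NC(=O)Nc2cc(F)cc(F)c2)c2ccccc2n1` is reported only as a limit, > 25000 nM.

Compound 4 `Cc1cc(NC(=O)Nc2ccc(C(N)=O)cc2)c2ccccc2n1` is next, and its difference from compound 2 is amino in place of methyl on a carbonyl carbon, or acetyl to carbamoyl. For the measured compounds named here, no measured step covers this change, so the expectation rests on compound 2 at 22000 nM, and no shift beyond the scatter is expected in this assay. The expected size of a 1.1-fold higher number from compound 2 to compound 4 (0.06 log units; within the scatter) is therefore small. A reported limit would not be a surprise, given (the limit of > 25000 nM in this assay, at which 1 of the 3 values shown sits). For compound 4 the estimated value is 25000 nM, with an expected range of 12000 nM to 50000 nM.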

Compound 4, half-maximal effective concentration: > 25000 nM
Compound 4: no number, only a limit; the forecaster's own chance of this, stated with the estimate: 55%; the middle value sits exactly at the limit.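

For the compounds shown here, the change of methyl to amino on a carbonyl carbon gives the first readable step, in this assay: an at least 1.1-fold higher number from compound 2 to compound 4 (0.05 log units; that floor lies within the scatter). Compound 4 is reported only as a limit, > 25000 nM. The step therefore gives a floor and not a size, so the change adds a hydrogen-bond donor without any shift beyond the scatter being shown, and limits now account for more of the series: the limit of > 25000 nM in this assay, at which 2 of the 4 values shown sit.

Going by these compounds, whether a carboxylic acid or a longer chain at this place would give a number rather than a limit stays open.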